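Turning the stereocentre of compound 2 to give compound 3

The source may hold more compounds than are shown below. What is called first, only, known or untested is meant among the compounds shown, and "the series" means these compounds.

Compound 1: `C[C@H](NC(=O)Nc1ccccc1C(F)(F)F)c1ccccc1` gives 98%
Compound 2: `C[C@@H](NC(=O)Nc1ccccc1F)c1ccccc1` gives 95%

Going by the values given here, the two compounds measured so far were tested in an ADME assay on the whole organism with Oryza sativa as the target, tested at 1 uM; a higher number here means a weaker effect of the compound at the concentration tested, a lower number a stronger effect. Compound 2 holds the lowest of the two numbers in this assay, yet its nearest neighbour, compound 1, lies only a little higher, a gap that stays within the scatter, so the two values cannot be set in order against each other.

Compound 3, `C[C@H](NC(=O)Nc1ccccc1F)c1ccccc1`, has not yet been measured in this assay. Its relation to compound 2 is the two compounds have the same atoms and bonds and differ only in configuration as drawn: 1 of 1 stereo elements differ; a stereocentre at a saturated chain carbon is drawn R in compound 2 and S in compound 3. Nothing leaves and nothing enters; the change is one of configuration alone. Among the compounds with values here, no step between measured compounds is available to size such a change here, so compound 3 is expected to stay close to compound 2, with a step of a number 1 percentage points higher from compound 2 to compound 3 (within the scatter) that does not go beyond the scatter in this assay. Compound 3 is therefore estimated at 96%, within a range from 88% to 100%.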

Compound 3, a percentage reported as activity, at one concentration (the size of the read-out at that concentration, not a potency): 92%
Beside the measured number, compound 3's estimate is 4 percentage points above it; low and high end bracket the measured number.
By their numbers in this assay, from the lowest: compounds 3, 2 and 1 (each within the scatter of the next).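

In this assay, turning the stereocentre at the saturated chain carbon from R to S gives a number 3 percentage points lower from compound 2 to compound 3 (within the scatter), so at this position the change of drawn configuration does not move the read-out beyond the scatter. Going by these compounds alone, with the configuration held as S, fluoro in place of trifluoromethyl on an aromatic carbon gives a number 6 percentage points lower from compound 1 to compound 3 (within the scatter), the first comparison of these two groups in which nothing else differs, and this exchange also stays inside the scatter. Any difference in the first of these comparisons could have only one structural origin: the fact that compounds 2 and 3 differ only in the configuration as drawn

The compounds shown leave open whether a different group on that aromatic carbon, such as an amine or a carboxylic acid, would give a step beyond the scatter. They also leave open whether the configuration at the stereocentre would matter in the presence of such a group.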